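The source may hold more compounds than are shown below. What is called first, only, known or untested is meant among the compounds shown, and "the series" means these compounds.

Of the compounds shown here, three built on one shared core have been measured in an ADME assay on HEp-2 cells (Homo sapiens) for cytotoxicity; a higher number here means that more compound is tolerated, a lower number that less compound is tolerated. Compound 1 (`CNCc1ccc2c(c1)nc(Cn1c(=O)n(C(C)C)c3ccccc31)n2CCC(C)C`), which carries a (methylamino)methyl group, gives 1480 nM. Compound 2 (`CC(C)CCn1c(Cn2c(=O)n(C(C)C)c3ccccc32)nc2cc(CO)ccc21`), with hydroxymethyl at that spot, gives 31600 nM, and compound 3 (`COC(=O)c1ccc2c(c1)nc(Cn1c(=O)n(C(C)C)c3ccccc31)n2CCC(C)C`), with methoxycarbonyl there, gives 33700 nM. Compound 3 therefore shares the high end of the three numbers with compound 2, as the step of a 1.1-fold higher number from compound 2 to compound 3 (0.03 log units; within the scatter) shows.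

Compound 4 (`CC(C)CCn1c(Cn2c(=O)n(C(C)C)c3ccccc32)nc2cc(C(N)=O)ccc21`) is made from compound 3 by one small edit: amino in place of methoxy on a carbonyl carbon. In words, amino takes the place of methoxy on a carbonyl carbon, so methoxycarbonyl becomes carbamoyl. For the measured compounds named here, no measured pair makes exactly this change, so the evidence is indirect. The two large steps, a 21-fold higher number from compound 1 to compound 2 (1.33 log units; beyond the scatter) and a 23-fold higher number from compound 1 to compound 3 (1.36 log units; beyond the scatter), both start from the (methylamino)methyl group, which compound 4 does not carry. The closest guide is the swap between two groups without it, the step of a 1.1-fold higher number from compound 2 to compound 3 (0.03 log units; within the scatter). Going by the values given here, with only three compounds this is thin support, but no step beyond the scatter is expected in this assay, and the estimated change is a 1.1-fold lower number from compound 3 to compound 4 (0.02 log units; within the scatter). The expected value for compound 4 is 32000 nM, within an estimated range of 13000 nM to 80000 nM.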

Compound 4, half-maximal cytotoxic concentration: 23400 nM
The estimate for compound 4 lay 1.4-fold (0.14 log units) above the measured number; low and high end bracket the measured number.
By their numbers in this assay, from the lowest: compound 1; then compounds 4, 2 and 3 (each within the scatter of the next).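

In this assay, the new result shows that replacing methoxy with amino on this carbonyl carbon stays within the scatter, a 1.4-fold lower number from compound 3 to compound 4 (0.16 log units; within the scatter), even though the entering amino counts as a hydrogen-bond donor and the leaving methoxy does not. Carbamoyl and hydroxymethyl on this aromatic carbon are likewise not separated, a 1.4-fold lower number from compound 2 to compound 4 (0.13 log units; within the scatter), so compounds 2, 3 and 4 form one group, while a large gap separates compound 1 from carbamoyl as well, a 16-fold higher number from compound 1 to compound 4 (1.20 log units; beyond the scatter). No measurement is available that would explain these numbers.

For the compounds shown here, what stays open is whether the much lower number of compound 1 goes with its amine specifically, as (methylamino)methyl is the only such group among the four compounds. A primary amine, a dimethylamine or a longer chain carrying an amine on this aromatic carbon would test that link, and a carboxylic acid or a methyl amide would show whether the other groups at this spot continue to stay within the scatter of one another.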